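The source may report more compounds than this note shows. Statements on the series, on what has been measured and on what is new or still open speak of the compounds shown alone.

Measured in a functional assay on MCF7 cells (Homo sapiens) for inhibition, read by MTT assay, with a stated time of 72 h; a lower number here means a stronger inhibitor, a higher number a weaker inhibitor:
Compound 1 `FC(F)(F)c1ccc(CSc2nc(N3CCN(c4ccccc4)CC3)cc(C(F)(F)F)n2)cc1`: > 50000 nM, a limit.
Compound 2 `FC(F)(F)c1ccc(CSc2nc(N3CCN(c4ncccn4)CC3)cc(C(F)(F)F)n2)cc1`: > 50000 nM, a limit.
Compound 3 `FC(F)(F)c1ccc(CSc2nc(Sc3ncccn3)cc(C(F)(F)F)n2)cc1`: > 50000 nM, a limit.

Among the compounds with values here, the only reading so far is the limit of > 50000 nM in this assay, at which 3 of the 3 values shown sit. Compound 3 therefore has no number, only the limit > 50000 nM.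

Compound 4 `FC(F)(F)c1ccc(CSc2nc(SC3=NCCS3)cc(C(F)(F)F)n2)cc1` keeps the rest of compound 3 and changes one group: a group of 5 heavy atoms (3 carbon, 1 nitrogen, 1 sulfur; one five-membered non-aromatic ring with 2 hetero atoms) in place of a group of 6 heavy atoms (4 carbon, 2 nitrogen; one six-membered aromatic ring with 2 hetero atoms), on a sulfur. Pyrimidin-2-yl leaves, and a five-membered non-aromatic ring with 2 hetero atoms enters, on a sulfur whose other neighbours are: aromatic carbon.

Within the data shown here, the one measured step is a step that the two limits leave unreadable from compound 1 to compound 2. It lies on an amine nitrogen in a ring, not on this sulfur, and it gives no size to carry over. Among the measured compounds shown here, no step of readable size is therefore expected in this assay, in either direction. The expected step is a number no higher from compound 3 to compound 4 (the limit leaves the size open).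

For compound 4 the estimate is 50000 nM, with an expected range of 15000 nM to 100000 nM.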

Compound 4, half-maximal inhibitory concentration: 44900 nM
Estimate against measurement, compound 4: 1.1-fold (0.05 log units) above; the range from low to high includes it.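

In this assay, putting the five-membered non-aromatic ring with 2 hetero atoms in place of pyrimidin-2-yl, on a sulfur whose other neighbours are: aromatic carbon, gives an at least 1.1-fold lower number from compound 3 to compound 4 (0.04 log units; that floor lies within the scatter). Compound 4 gives 44900 nM, the only actual number among the compounds shown, so a change on this sulfur can bring the read-out inside the measurable range. How large the step really is stays open, because compound 3 has only a limit, as do compound 1 and compound 2: the limit of > 50000 nM in this assay, at which 3 of the 4 values shown sit.

Which feature of the entering ring matters cannot be told from this single change, whether its ring sulfur, its double bond or its ring size. As far as these compounds go, how an ethyl chain or a carboxylic acid on this sulfur would read in this assay also remains open.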